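This account rests on a few compounds, and the source may have more. Where it says the series, first, only, none or still open, it means among the compounds named here.

Measured so far:
Compound 1 `O=C(Nc1ccc(Cl)cc1)C1CCCN(C(=O)c2cccc(-c3nccs3)c2)C1`: 32%
Compound 2 `COC(=O)c1cccc(C(=O)N2CCCC(C(=O)Nc3ccc(Cl)cc3)C2)c1`: 0%

In an ADME assay on PC-3 cells (Homo sapiens) for cytotoxicity, read by WST assay, tested at 100 uM (a lower number here means less inhibition, a higher number more inhibition at the concentration tested (going by the name of the read-out)), compound 2 gives the lowest of the two numbers; its nearest neighbour is compound 1, and the change from one to the other, a number 32 percentage points lower from compound 1 to compound 2 (beyond the scatter), lies beyond the scatter. Compound 3 `O=C(Nc1ccc(Cl)cc1)C1CCCN(C(=O)c2cccc([N+](=O)[O-])c2)C1` has not been measured. It differs from compound 2 in one place: nitro in place of methoxycarbonyl on an aromatic carbon. Going by the values given here, no measured step involves a nitro group, so the only step that bears on this position is the one from compound 1 to compound 2, which was large. Since a nitro group is a different kind of substituent from either of those, that step gives only weak guidance, and a small upward move within or near the scatter is expected, a number 10 percentage points higher from compound 2 to compound 3 (within the scatter). Compound 3 is therefore estimated at 10%, with a range from 0% to 35%.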

Compound 3, a percentage reported as inhibition, at one concentration (the size of the read-out at that concentration, not a potency): 0%
For compound 3 the middle estimate is 10 percentage points above the measured one; measured number inside the range.
By their numbers in this assay, from the lowest: compounds 2 and 3 (each within the scatter of the next); then compound 1.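

In this assay, nitro in place of methoxycarbonyl, on an aromatic carbon meta to a large group, gives no change at the digits printed from compound 2 to compound 3 (within the scatter). Set against 1,3-thiazol-2-yl, nitro gives a number 32 percentage points lower from compound 1 to compound 3 (beyond the scatter), matching a number 32 percentage points lower from compound 1 to compound 2 (beyond the scatter), so two different replacements now fall on the same side of that large step, and among these three compounds only compound 1 stands apart. Nothing given here accounts for that separation.

Going by these compounds, whether an amine or a carboxylic acid at this position would read with compound 1, or with compound 2 and compound 3, remains open. Also open, on these data alone, is whether a simple phenyl group would keep the reading of compound 1, or whether that reading is particular to 1,3-thiazol-2-yl.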